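Moving the nitrophenyl: from compound 2 to compound 3

The source may report more compounds than this note shows. Statements on the series, on what has been measured and on what is new or still open speak of the compounds shown alone.

Compound 1 `O=C(Nc1ccccc1[N+](=O)[O-])c1ccc(/N=N\c2c[nH]c3ccccc23)cc1` gives 77900 nM in a functional assay on P388 cells (Mus musculus) for inhibition, read by MTT assay, with a stated time of 72 h; a higher number here means a weaker inhibitor, a lower number a stronger inhibitor.
Compound 2 `O=C(Nc1ccc([N+](=O)[O-])cc1)c1ccc(/N=N\c2c[nH]c3ccccc23)cc1` gives 11200 nM in this assay.

Among the compounds with values here, compound 2 holds the lower of the two numbers measured so far. Within the data shown here, the one measured step, a 7.0-fold lower number from compound 1 to compound 2 (0.84 log units; beyond the scatter), is the only guide. Compound 3 `O=C(Nc1cccc([N+](=O)[O-])c1)c1ccc(/N=N\c2c[nH]c3ccccc23)cc1` differs from compound 2 by 3-nitrophenyl in place of 4-nitrophenyl on an amide-type nitrogen. Among the measured compounds shown here, no measured step shows what a 3-nitrophenyl does, so only a loose expectation is possible: a rise in the number, smaller than the gap between compound 1 and compound 2. Compound 3 is therefore estimated at 25000 nM, within 6000 nM to 90000 nM, which means an expected step of a 2.2-fold higher number from compound 2 to compound 3 (0.35 log units; beyond the scatter).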

Compound 3, half-maximal inhibitory concentration: 51900 nM
For compound 3 the middle estimate is 2.1-fold (0.32 log units) below the measured one, and the stated range covers the measured number.
By their numbers in this assay, from the lowest: compound 2; then compounds 3 and 1 (each within the scatter of the next).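

The 3-nitrophenyl does not keep the standing of the 4-nitrophenyl: this assay shows a 4.6-fold higher number from compound 2 to compound 3 (0.67 log units; beyond the scatter) for this change on the amide-type nitrogen. Against the 2-nitrophenyl, the same assay gives a 1.5-fold lower number from compound 1 to compound 3 (0.18 log units; within the scatter), so those two compounds cannot be told apart, and among these three the 4-nitrophenyl alone stands out. Nothing available explains why the place of the nitro group matters here.

Still open, going by these compounds, is whether the nitro group is needed at all. An amine or a carboxylic acid in its place on the phenyl ring might keep, lose or improve the number of compound 2.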